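Aryl swap at the chain carbon in the enone series

A few compounds are considered here, and "the series" means these few. Any claim that something is new, unique, unknown or untested is made for them only; others in the source may bear on it.

Three compounds carry the same core. Compound 1 `CN(C)c1ccc(/C=C(/SCc2ccc(F)cc2)C(=O)c2ccc(Br)cc2)cc1` gives 50000 nM in a functional assay on DU-145 cells (Homo sapiens) for inhibition, read by trypan blue exclusion, with a stated time of 96 h; on this read-out higher numbers stand for weaker inhibition of growth and lower numbers for stronger inhibition of growth; compound 2 `Cc1ccsc1/C=C(/SCc1ccc(F)cc1)C(=O)c1ccc(Br)cc1` gives 50000 nM; compound 3 `Cc1ccsc1/C=C(/SCc1ccc(Cl)cc1)C(=O)c1ccc(Br)cc1` gives 25000 nM. Compound 2 stands level with compound 1, together the highest two of the three numbers; the nearest is compound 1 with no change at the digits printed from compound 1 to compound 2 (within the scatter), the furthest is compound 3 with a 2.0-fold lower number from compound 2 to compound 3 (0.30 log units; within the scatter).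

Compound 4 `COc1ccc(/C=C(/SCc2ccc(F)cc2)C(=O)c2ccc(Br)cc2)cc1O` is not yet measured. Its change from compound 2 is 3-hydroxy-4-methoxyphenyl in place of 3-methylthiophen-2-yl on a double-bonded chain carbon bound to a double-bonded chain carbon. Within the data shown here, only one measured step touches the same place, and that is no change at the digits printed from compound 1 to compound 2 (within the scatter), which shows that exchanging the aryl group on the double-bonded chain carbon left the number unmoved. The step of a 2.0-fold lower number from compound 2 to compound 3 (0.30 log units; within the scatter) concerns another position and sits within the scatter. No step beyond the scatter is expected for compound 4, in either direction, no change at the digits printed from compound 2 to compound 4 (within the scatter). The estimate for compound 4 is therefore 50000 nM, with an expected range from 20000 nM to 100000 nM.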

Compound 4, concentration for 50% growth inhibition: 1000 nM
Compound 4: middle estimate off by 50-fold (1.70 log units), on the high side, and the stated range ends above it.
By their numbers in this assay, from the lowest: compound 4; then compounds 3, 1 and 2 (each within the scatter of the next).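

In this assay the aryl group on the double-bonded chain carbon proves to be a position that can move the number: 3-hydroxy-4-methoxyphenyl in place of 3-methylthiophen-2-yl gives a 50-fold lower number from compound 2 to compound 4 (1.70 log units; beyond the scatter) and in place of 4-(dimethylamino)phenyl gives a 50-fold lower number from compound 1 to compound 4 (1.70 log units; beyond the scatter). The only earlier exchange at this place, no change at the digits printed from compound 1 to compound 2 (within the scatter), gave no sign of this, so among the three aryl groups shown, the position separates 3-hydroxy-4-methoxyphenyl from the other two, which stand level with each other. Nothing available explains this gap.

Compound 4 carries the hydroxy and the methoxy group on one ring, and the compounds shown do not separate their contributions. Also open, on these data alone, are how a carboxylic acid in place of the hydroxy group would read and whether chloro in place of fluoro would change the number on the core of compound 4.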